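Methyl to fluoro on the aryl of a triazole sulfonamide

This account rests on a few compounds, and the source may have more. Where it says the series, first, only, none or still open, it means among the compounds named here.

Two sulfonamides of one shared core have been measured. In an ADME assay on L02 cells (Homo sapiens) for cytotoxicity, read by MTT assay, with a stated time of 24 h (on this read-out lower numbers stand for higher toxicity in this test and higher numbers for lower toxicity in this test), compound 1 `O=c1[nH]cc(S(=O)(=O)Nc2ccccc2-c2cn(-c3ccc(Cl)cc3)nn2)c(=O)[nH]1` gives 16800 nM. Compound 2 `Cc1cccc(-n2cc(-c3ccc(NS(=O)(=O)c4c[nH]c(=O)[nH]c4=O)cc3)nn2)c1`, in this assay, gives 39000 nM, the higher of the two numbers, its nearest neighbour being compound 1 at a lower number, beyond the scatter. Compound 3 `O=c1[nH]cc(S(=O)(=O)Nc2ccc(-c3cn(-c4cccc(F)c4)nn3)cc2)c(=O)[nH]1` differs from compound 2 by fluoro in place of methyl on an aromatic carbon. Among the compounds with values here, no measured pair shows this change, so the step of a 1.1-fold lower number from compound 2 to compound 3 (0.05 log units; within the scatter) is expected to stay within the scatter, in no set direction. Compound 3 is estimated at 35000 nM, between 15000 nM and 80000 nM.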

Compound 3, half-maximal cytotoxic concentration: "not toxic" (no number reported)
The entry for compound 3 holds no number; there is nothing to compare the estimate with.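

Within the data shown here, compound 3 is recorded only as "not toxic", without a number, so no step from compound 2 to compound 3 can be read. The compounds shown leave open whether fluoro in place of methyl changes this read-out at all. Nothing shown offers an explanation for this result.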